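The source may hold more compounds than are shown below. What is called first, only, known or untested is meant among the compounds shown, and "the series" means these compounds.

Compound 1 `CCOC(=O)c1sc(-c2cccc(NC(=O)c3cccc(F)c3)c2)nc1Nc1ccc(N2CCN(C)CC2)cc1` gives 85.2% in a functional assay on Ramos cells (Homo sapiens) for antiproliferative activity, read by CCK-8 assay, with a stated time of 72 h, tested at 40 uM; on this read-out higher numbers stand for more inhibition at the one concentration tested (going by the name of the read-out) and lower numbers for less inhibition.
Compound 2 `CCOC(=O)c1sc(-c2cccc(NC(=O)c3ccc(C(F)(F)F)cn3)c2)nc1Nc1ccc(N2CCN(C)CC2)cc1` gives 19% in this assay.

On the two numbers shown, compound 2 stands lowest; the only step recorded, a number 66.2 percentage points lower from compound 1 to compound 2 (beyond the scatter), came from exchanging 3-fluorophenyl for 5-(trifluoromethyl)pyridin-2-yl on a carbonyl carbon. Compound 3 `CN1CCN(c2ccc(Nc3nc(-c4cccc(NC(=O)c5ccc(C(F)(F)F)cn5)c4)sc3C(N)=O)cc2)CC1` differs from compound 2 at another carbonyl carbon: amino in place of ethoxy on a carbonyl carbon. The ethoxycarbonyl-to-carbamoyl change has no measured counterpart among these compounds, so the one recorded step does not bear on it, and nothing here shows how amino in place of ethoxy shifts the read-out. The expectation for compound 3 therefore stays near compound 2, with a wide range to reflect the missing precedent. Compound 3 is expected to shift by a number 6 percentage points higher from compound 2 to compound 3 (within the scatter), a step not beyond the scatter. Compound 3 is estimated at 25%, between 5% and 60%.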

Compound 3, a percentage reported as inhibition, at one concentration (the size of the read-out at that concentration, not a potency): 96.6%
Compound 3: middle estimate off by 71.6 percentage points, on the low side, outside the stated range (above it).
By their numbers in this assay, from the lowest: compound 2; then compound 1; then compound 3.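

In this assay, the carbonyl carbon whose other neighbour is an aromatic carbon turns out to be a place where one small exchange can decide the read-out: ethoxycarbonyl to carbamoyl gives a number 77.6 percentage points higher from compound 2 to compound 3 (beyond the scatter). The earlier step had shown only a loss at the other carbonyl carbon, with ethoxy held constant; this one shows that the low reading of compound 2 is not set by 5-(trifluoromethyl)pyridin-2-yl alone. Nothing available explains why amino and ethoxy differ so much here.

Going by these compounds, whether amino brings the same gain alongside 3-fluorophenyl remains open. So does the outcome with other groups on this carbonyl carbon, such as methylamino, a carboxylic acid or a longer ester chain.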